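This account rests on a few compounds, and the source may have more. Where it says the series, first, only, none or still open, it means among the compounds named here.

In a functional assay on CCRF-CEM cells (Homo sapiens), read by MTT assay, with a stated time of 72 h (on this read-out higher numbers stand for weaker inhibition and lower numbers for stronger inhibition), compound 1 `COc1ncnc2c1c(-c1ccccc1)cn2[C@@H]1O[C@H](CO)[C@@H](O)[C@H]1O` gives > 20000 nM as a limit, not a number. Among the measured compounds shown here, compound 2 `CSc1ncnc2c1c(-c1ccoc1)cn2[C@@H]1O[C@H](CO)[C@@H](O)[C@H]1O` at 14200 nM holds the only actual number in this assay so far. Compound 3 `CSc1ncnc2c1c(-c1cccs1)cn2[C@@H]1O[C@H](CO)[C@@H](O)[C@H]1O` differs from it on the shared core by thiophen-2-yl in place of furan-3-yl on an aromatic carbon with thiophen-2-yl in place of furan-3-yl on an aromatic carbon. For the measured compounds named here, no measured step shows what such an exchange does, so only a modest shift towards stronger inhibition is expected in this assay with the estimated 2.0-fold lower number from compound 2 to compound 3 (0.31 log units; beyond the scatter) remaining small. For compound 3 the estimated value is 7000 nM within an expected range from 1500 nM to 20000 nM in this measurement.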

Compound 3, half-maximal inhibitory concentration: > 20000 nM
Compound 3 gave a limit, no number; the forecaster's own chance of this, stated with the estimate: 20%; middle value at least 2.8-fold (0.45 log units) away from the limit.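

In this assay, among the compounds shown here, replacing furan-3-yl with thiophen-2-yl on this aromatic carbon gives an at least 1.4-fold higher number from compound 2 to compound 3 (0.14 log units; that floor lies within the scatter), the first measured step at this position. It shows that this exchange of one five-membered aromatic ring for another brings no stronger inhibition, although the result for compound 3 is a limit and the step only a floor. The weak end of this series is thus poorly resolved: the limit of > 20000 nM in this assay, at which 2 of the 3 values shown sit.

On these data alone, how far compound 3 lies past its limit remains open. So does whether an amine or a longer alkyl chain on this aromatic carbon would give a lower number than compound 2.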